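A few compounds are considered here, and "the series" means these few. Any claim that something is new, unique, unknown or untested is made for them only; others in the source may bear on it.

Series notes on the shared core of compound 1, `OCCNc1nnc2nncn2n1`, which in a functional assay on BeWo cells (Homo sapiens) for inhibition, read by MTT assay, with a stated time of 72 h (on this read-out higher numbers stand for weaker inhibition and lower numbers for stronger inhibition), gives 3310 nM. Compound 2, `CCCCC(=O)N1CCN(c2nnc3nncn3n2)CC1`, gives 1720 nM in this assay, and compound 3, `CC(=O)N1CCN(c2nnc3nncn3n2)CC1`, gives 13100 nM. Compound 3 thus stands with the highest number of the three measured: compound 2 is furthest from it, compound 1 is nearest, and both gaps are beyond the scatter.

Going by the values given here, the one measured step that bears on the present change is a 7.6-fold higher number from compound 2 to compound 3 (0.88 log units; beyond the scatter). The unmeasured compound 4, `CCC(=O)N1CCN(c2nnc3nncn3n2)CC1`, differs from compound 3 by methyl in place of hydrogen on a saturated chain carbon bound to a carbonyl carbon. Among the compounds with values here, this puts back part of what was removed between compound 2 and compound 3 and lies between those two compounds in what sits on the saturated chain carbon bound to the carbonyl carbon; the series holds no other pair that tests this spot.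

On that basis, a lowering of the number is expected for compound 4 in this assay, smaller than the step between compound 2 and compound 3 because a 7.6-fold higher number from compound 2 to compound 3 (0.88 log units; beyond the scatter) covered the full removal of propyl. The expected step is a 2.2-fold lower number from compound 3 to compound 4 (0.34 log units; beyond the scatter). Compound 4 is therefore estimated at 6000 nM, within a range from 2500 nM to 14000 nM.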

Compound 4, half-maximal inhibitory concentration: 13700 nM
Estimate against measurement, compound 4: 2.3-fold (0.36 log units) below; low and high end bracket the measured number.
By their numbers in this assay, from the lowest: compounds 2 and 1 (each within the scatter of the next); then compounds 3 and 4 (each within the scatter of the next).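

In this assay, the methyl added to the saturated chain carbon bound to a carbonyl carbon leaves compound 3 and compound 4 within the scatter of each other (a 1.0-fold higher number from compound 3 to compound 4 (0.02 log units; within the scatter)), so going from acetyl to propanoyl alone does not separate them. The step to the longer chain of compound 2 remains beyond the scatter when read from propanoyl (an 8.0-fold higher number from compound 2 to compound 4 (0.90 log units; beyond the scatter)) just as when read from acetyl (a 7.6-fold higher number from compound 2 to compound 3 (0.88 log units; beyond the scatter)), so across these three compounds the number does not move in proportion to each carbon added, and the change shows up only with the further length present in compound 2. No measured evidence explains why this first added carbon leaves the number in place while the longer chain does not.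

The compounds shown leave open at what length the step appears, which a butanoyl group would help to place, and whether a hexanoyl or still longer chain carries it further. They also leave open whether a branched isobutyryl group, or an amine or carboxylic acid at the end of the chain, would behave as compound 2 does or as compound 4 does.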